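A few compounds are considered here, and "the series" means these few. Any claim that something is new, unique, unknown or untested is made for them only; others in the source may bear on it.

Measured so far in a functional assay on HCT-116 cells (Homo sapiens) for antiproliferative activity, read by sulforhodamine B assay, with a stated time of 72 h; a lower number here means a stronger inhibitor, a higher number a weaker inhibitor:
Compound 1 `Nc1nc(N2CCN(c3ncccn3)CC2)c2ncn([C@@H]3O[C@H](CO)[C@@H](O)[C@H]3O)c2n1`: "not active" (no number reported)
Compound 2 `CC(C)c1ccc(Nc2ncnc3c2ncn3[C@@H]2O[C@H](CO)[C@@H](O)[C@H]2O)cc1`: 10000 nM

Only compound 2 has a number, so its 10000 nM is the sole numerical reference point, and there is no series of values to rank it against. Compound 1 shares much of its core but gave no number. Compound 3 `OC[C@H]1O[C@@H](n2cnc3c(NCCNc4ccccc4)ncnc32)[C@H](O)[C@@H]1O` is not yet measured. It has 2-anilinoethyl in place of 4-isopropylphenyl on a nitrogen on an aromatic ring. Among the measured compounds shown here, no measured step shows what such a swap does, so the expectation is cautious. In this assay, the expected step of a 1.5-fold higher number from compound 2 to compound 3 (0.18 log units; within the scatter) stays within the usual scatter, with a slight lean toward weaker inhibition. A result with no number would be no surprise. For compound 3, the estimated value is 15000 nM, with an expected range of 4000 nM to 50000 nM.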

Compound 3, half-maximal inhibitory concentration: 30000 nM
The estimate for compound 3 lay 2.0-fold (0.30 log units) below the measured number; measured number inside the range.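

In this assay, among the compounds shown here, the swap of 4-isopropylphenyl for 2-anilinoethyl on a nitrogen on an aromatic ring gives a 3.0-fold higher number from compound 2 to compound 3 (0.48 log units; beyond the scatter) and so provides the first measured step at this position. The two groups match in heavy-atom count and each holds one six-membered aromatic ring of carbon only, yet the change is beyond the usual scatter, so this position does respond to the group placed on it. 2-Anilinoethyl adds a nitrogen with a hydrogen-bond donor and acceptor, but nothing measured here explains the weaker result.

This single step cannot separate the effect of that added nitrogen from the effect of the different chain linking the ring. As far as these compounds go, how a benzyl group, a 3-phenylpropyl chain or a carboxylic acid on this nitrogen would compare remains open.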